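The source may hold more compounds than are shown below. What is called first, only, known or untested is meant among the compounds shown, and "the series" means these compounds.

Compound 3 `N#Cc1cc2c(nc1N1CCC(C(=O)NS(=O)(=O)Cc3ccccc3F)CC1)COC2=O` gives 23700 nM in a functional assay (Platelet, plasma) for inhibition, with Homo sapiens as the target (on this read-out lower numbers stand for stronger inhibition and higher numbers for weaker inhibition), the highest of the three numbers in hand. Its neighbours are compound 1 `CC1(C(=O)NS(=O)(=O)Cc2ccc(F)cc2F)CCN(c2nc3c(cc2C#N)C(=O)OC3)CC1`, which gives 8760 nM, and compound 2 `N#Cc1cc2c(nc1N1CCC(C(=O)NS(=O)(=O)Cc3ccc(Cl)cc3)CC1)COC2=O`, which gives 4420 nM. Compound 4 `N#Cc1cc2c(nc1N1CCC(C(=O)NS(=O)(=O)Cc3ccc(F)cc3F)CC1)COC2=O` has not yet been measured; it differs from compound 3 by fluoro in place of hydrogen on an aromatic carbon.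

Among the measured compounds shown here, one measured step bears on this change: a 5.4-fold higher number from compound 2 to compound 3 (0.73 log units; beyond the scatter), in which the substituent on the benzyl ring was exchanged. For the measured compounds named here, compound 1 carries the same 2,4-difluorobenzyl as compound 4 but also a methyl on the chain carbon bearing the carbonyl, so no single-point step joins it to compound 3 or compound 4; its number simply sits well under that of compound 3. Both observations point the same way, so a move to a lower number is expected for compound 4, of a size somewhat under the step from compound 2 to compound 3. The expected move is a 2.6-fold lower number from compound 3 to compound 4 (0.42 log units; beyond the scatter). Compound 4 is therefore estimated at 9000 nM, with a range of 4000 nM to 20000 nM.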

Compound 4, half-maximal inhibitory concentration: 5200 nM
Compound 4: the middle estimate sits 1.7-fold (0.24 log units) above what was measured; low and high end bracket the measured number.
By their numbers in this assay, from the lowest: compounds 2, 4 and 1 (each within the scatter of the next); then compound 3.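

Fluoro in place of hydrogen on this aromatic carbon, para to a large group, gives a 4.6-fold lower number from compound 3 to compound 4 (0.66 log units; beyond the scatter) in this assay, so the position responds to the change even with the 2-fluoro group kept in place. The 4-chlorophenyl and 2,4-difluorophenyl groups are not told apart, with a 1.2-fold higher number from compound 2 to compound 4 (0.07 log units; within the scatter), and hydrogen in place of methyl on the saturated ring carbon gives a 1.7-fold lower number from compound 1 to compound 4 (0.23 log units; within the scatter), so neither of these two changes moves the number beyond the scatter. No measurement at hand accounts for the response at this carbon.

Open, from the compounds shown here alone, is whether the response is confined to halogens at this carbon, which a methoxy or an amine there would test. Also open, going by these compounds, is whether the 2-fluoro group contributes at all, which a 4-fluorobenzyl on the same core would test.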